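Trading Butyl for Methylsulfanyl: What to Expect

The source may report more compounds than this note shows. Statements on the series, on what has been measured and on what is new or still open speak of the compounds shown alone.

In an assay on HEK293 cells for inhibition of N-acylethanolamine-hydrolyzing acid amidase (Homo sapiens), read by fluorescence, with stated times of 10 min and 50 min (on this read-out lower numbers stand for stronger inhibition and higher numbers for weaker inhibition), compound 1 `CON1C[C@H](NC(=O)OCCCCC2CCCCC2)C1=O` gives 16 nM, compound 2 `CCCCCON1C(=O)[C@@H](NC(=O)OCCCCC2CCCCC2)[C@@H]1C` gives 387 nM, and compound 3 `CCCCCCCON1C(=O)[C@@H](NC(=O)OCCCCC2CCCCC2)[C@@H]1C` gives 2230 nM. Compound 3 thus carries the highest number of the three, meaning the weakest inhibition. Among the measured compounds shown here, the one measured single-change step is a 5.8-fold higher number from compound 2 to compound 3 (0.76 log units; beyond the scatter), where the chain grew from pentyl to heptyl. Compound 4 `CSCCCON1C(=O)[C@@H](NC(=O)OCCCCC2CCCCC2)[C@@H]1C` differs from compound 3 by methylsulfanyl in place of butyl on a saturated chain carbon, three bonds along the chain from an oxygen on an unsaturated carbon; read one bond further out, heptyl becomes 3-(methylsulfanyl)propyl, a chain resembling the pentyl of compound 2. Because a 5.8-fold higher number from compound 2 to compound 3 (0.76 log units; beyond the scatter) was a modest step beyond the scatter, a step back in the opposite direction in this assay is expected, roughly a 4.5-fold lower number from compound 3 to compound 4 (0.65 log units; beyond the scatter). Compound 4 is therefore estimated at 500 nM, within 150 nM to 1700 nM.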

Compound 4, half-maximal inhibitory concentration: 167 nM
Estimate against measurement, compound 4: 3.0-fold (0.48 log units) above; the range from low to high includes it.
By their numbers in this assay, from the lowest: compound 1; then compound 4; then compound 2; then compound 3.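

Putting methylsulfanyl in place of butyl, on a saturated chain carbon three bonds along the chain from an oxygen on an unsaturated carbon, gives a 13-fold lower number from compound 3 to compound 4 (1.13 log units; beyond the scatter) in this assay, so the far end of this chain strongly affects the reading. The change does more than undo the chain growth, since methylsulfanyl in place of ethyl gives a 2.3-fold lower number from compound 2 to compound 4 (0.36 log units; beyond the scatter), a step beyond the scatter. Nothing available explains this difference.

A 3-methoxypropyl chain here would test whether the sulfur itself matters. A shorter propyl chain would show whether trimming this chain further changes the reading.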